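A few compounds are considered here, and "the series" means these few. Any claim that something is new, unique, unknown or untested is made for them only; others in the source may bear on it.

Compound 1 `Cc1ccc2oc(/C=C/[S+](C)[O-])cc(=O)c2c1` gives 7000 nM in a functional assay on DLD-1 cells (Homo sapiens) for cytotoxicity, with a stated time of 48 h; on this read-out lower numbers stand for stronger inhibition and higher numbers for weaker inhibition.
Compound 2 `CC(C)CCOc1ccc2oc(/C=C/[S+](C)[O-])cc(=O)c2c1` gives 4100 nM in this assay.
Compound 3 `CC(C)Oc1ccc2oc(/C=C/[S+](C)[O-])cc(=O)c2c1` gives 8000 nM in this assay.

Compound 3 carries the highest of the three numbers, but both its neighbours sit within the scatter: a 1.1-fold higher number from compound 1 to compound 3 (0.06 log units; within the scatter) and a 2.0-fold higher number from compound 2 to compound 3 (0.29 log units; within the scatter). Among the measured compounds shown here, the series so far varies only the substituent on the shared core, and no step in it, including a 1.7-fold lower number from compound 1 to compound 2 (0.23 log units; within the scatter), leaves the scatter.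

Compound 4 `CC(C)CC(=O)Oc1ccc2oc(/C=C/[S+](C)[O-])cc(=O)c2c1` is the next variation on the oxygen on an aromatic ring: isobutylcarbonyl in place of isopropyl on an oxygen on an aromatic ring. The step that bears most directly on it is the chain change on that same oxygen, a 2.0-fold higher number from compound 2 to compound 3 (0.29 log units; within the scatter), which was flat. Nothing here supports a shift beyond the scatter in this assay, so the expected step is a 1.2-fold lower number from compound 3 to compound 4 (0.09 log units; within the scatter). Compound 4 is therefore estimated at 6500 nM, with a range of 2500 nM to 16000 nM.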

Compound 4, half-maximal inhibitory concentration: 6100 nM
For compound 4 the middle estimate is 1.1-fold (0.03 log units) above the measured one; measured number inside the range.
By their numbers in this assay, from the lowest: compounds 2, 4, 1 and 3 (each within the scatter of the next).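

Exchanging the ether chains on the oxygen on an aromatic ring for isobutylcarbonyl adds a double bond outside aromatic rings and a hydrogen-bond acceptor, yet in this assay neither step on that oxygen leaves the scatter (a 1.3-fold lower number from compound 3 to compound 4 (0.12 log units; within the scatter); a 1.5-fold higher number from compound 2 to compound 4 (0.17 log units; within the scatter)). The comparison with the methyl on an aromatic carbon reads the same (a 1.1-fold lower number from compound 1 to compound 4 (0.06 log units; within the scatter)), so all the variations shown at this place remain flat. No measurement here accounts for this flatness.

From the compounds shown here alone, whether an amine, a carboxylic acid or a much longer chain on that oxygen would leave the scatter remains open. So does whether changes elsewhere on the shared core would matter.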